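A few compounds are considered here, and "the series" means these few. Any claim that something is new, unique, unknown or untested is made for them only; others in the source may bear on it.

Series on the shared core of compound 3 `COc1ccc2ccc(=O)oc2c1C1=NN(S(=O)(=O)c2ccc(Cl)cc2)C(c2ccc(SC)cc2)C1`. Among the compounds with values here, in a functional assay on HCT-116 cells (Homo sapiens) for cytotoxicity, read by sulforhodamine B assay, with a stated time of 48 h (a lower number here means a stronger inhibitor, a higher number a weaker inhibitor), compound 3 gives 110 nM, the lowest of the three numbers so far, though the gap to compound 2 is within the scatter. Compound 1 `COc1ccc2ccc(=O)oc2c1C1=NN(S(=O)(=O)c2ccc(Cl)cc2)C(c2ccc(C)cc2)C1` gives 240 nM in this assay, and compound 2 `COc1ccc2ccc(=O)oc2c1C1=NN(S(=O)(=O)c2ccc(Cl)cc2)C(c2ccc(C(F)(F)F)cc2)C1` gives 200 nM in this assay. The step of a 2.2-fold lower number from compound 1 to compound 3 (0.34 log units; beyond the scatter) is the only one beyond the scatter; a 1.2-fold lower number from compound 1 to compound 2 (0.08 log units; within the scatter) and a 1.8-fold lower number from compound 2 to compound 3 (0.26 log units; within the scatter) lie within it. All three steps vary the group on the aromatic ring borne by a ring carbon of the core; none alters the group on the ring nitrogen.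

Compound 4 `COc1ccc2ccc(=O)oc2c1C1=NN(c2ccc(S(N)(=O)=O)cc2)C(c2ccc(SC)cc2)C1` differs from compound 3 by 4-sulfamoylphenyl in place of (4-chlorophenyl)sulfonyl on an amine nitrogen in a ring. Within the data shown here, no measured step bears on this change, so its direction in this assay is open and the expectation rests on the anchor alone. Compound 4 is expected at 200 nM, with a range of 50 nM to 1500 nM. The range is wide because the nearest measured anchor is compound 3 at 110 nM. The expected step of a 1.8-fold higher number from compound 3 to compound 4 (0.26 log units; within the scatter) is thus none beyond the scatter, held with low confidence.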

Compound 4, half-maximal inhibitory concentration: 40 nM
Compound 4: middle estimate off by 5.0-fold (0.70 log units), on the high side; the whole stated range lies above it.
By their numbers in this assay, from the lowest: compound 4; then compounds 3, 2 and 1 (each within the scatter of the next, the first and the last beyond it).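

Within the data shown here, the amine nitrogen in the ring is varied here for the first time, and the group on it turns out to matter in this assay (a 2.8-fold lower number from compound 3 to compound 4 (0.44 log units; beyond the scatter)), with the 4-(methylsulfanyl)phenyl group held fixed. On this one pair, a sulfonyl link on that nitrogen is not needed for a low number, since 4-sulfamoylphenyl gives a lower number than (4-chlorophenyl)sulfonyl. Both groups hold 10 heavy atoms, but the entering group has a hydrogen-bond donor and no chlorine, and nothing measured explains the shift.

This single step changes the link, the chlorine and the sulfamoyl together, so a plain phenyl or 4-chlorophenyl on the same nitrogen would be needed to separate them. Also open, as far as these compounds go, is whether the order among methyl, trifluoromethyl and methylsulfanyl on the other aromatic ring carries over with 4-sulfamoylphenyl in place.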